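Methyl for Fluoro on a Shared Anilide Core

The source may report more compounds than this note shows. Statements on the series, on what has been measured and on what is new or still open speak of the compounds shown alone.

Measured so far:
- compound 1 `Cc1ccc(N2CCCC2)c(C(=O)Nc2ccc(CNC(=O)OCc3cccnc3)cc2)c1`: 40600 nM
- compound 2 `O=C(NCc1ccc(NC(=O)c2cccc(F)c2N2CCCC2)cc1)OCc1cccnc1`: > 100000 nM, a limit of the assay
- compound 3 `O=C(NCc1ccc(NC(=O)c2cc(F)ccc2N2CCCC2)cc1)OCc1cccnc1`: > 100000 nM, a limit of the assay

In a toxicity assay on WI-38 cells (Homo sapiens) for inhibition, read by MTT assay, with a stated time of 72 h (on this read-out higher numbers stand for weaker inhibition and lower numbers for stronger inhibition), compound 1 gives 40600 nM. Compound 2 gives > 100000 nM, which is a limit of the assay and not a number. Compound 3 likewise gives > 100000 nM, again a limit. Compound 2 and compound 3 are built from the same atoms joined differently; the difference between the two cores is not broken down here.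

One change has been measured. From compound 3 to compound 1 the change is methyl in place of fluoro on an aromatic carbon, and it gives an at least 2.4-fold lower number from compound 3 to compound 1 (0.39 log units; beyond the scatter).

Compound 4 `Cc1cccc(C(=O)Nc2ccc(CNC(=O)OCc3cccnc3)cc2)c1N1CCCC1` has not yet been measured in this assay. It differs from compound 2 by methyl in place of fluoro on an aromatic carbon. The surroundings are not identical: in compound 1 the methyl sits para to a pyrrolidin-1-yl group, whereas in compound 4 it sits ortho to a pyrrolidin-1-yl group, so this is the same kind of change rather than the same change.

The step from compound 2 to compound 4 is expected to be an at least 1.6-fold lower number from compound 2 to compound 4 (0.22 log units; that floor lies within the scatter), resting on the measured step of an at least 2.4-fold lower number from compound 3 to compound 1 (0.39 log units; beyond the scatter), tempered because the limit of > 100000 nM in this assay, at which 2 of the 3 values shown sit, leaves the size of that step open-ended. Compound 4 is therefore estimated at 60000 nM, with a plausible span from 25000 nM to 200000 nM, and a real chance that only a limit is reported.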

Compound 4, half-maximal inhibitory concentration: > 100000 nM
Compound 4: only a limit was reported (the forecaster's own chance of this, stated with the estimate: 45%); at least 1.6-fold (0.22 log units) between middle value and limit.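

Compound 2 and compound 4 both sit at a limit rather than at a number in this assay, so no step can be read between them, and the size of this change stays unknown: the limit of > 100000 nM in this assay, at which 3 of the 4 values shown sit.

The compounds shown leave open whether methyl in place of fluoro, ortho to a pyrrolidin-1-yl group, changes the number at all, and by how much.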